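A second methyl on a shared core: does history repeat?

The source may report more compounds than this note shows. Statements on the series, on what has been measured and on what is new or still open speak of the compounds shown alone.

The measure throughout is an assay on HEK293-TREx cells for antagonist activity at transient receptor potential cation channel subfamily A member 1 (Homo sapiens), read by fluorescence and calcium flux, with a stated time of 72 h; on this read-out lower numbers stand for stronger inhibition and higher numbers for weaker inhibition. Compound 1, with the structure `c1ccc(Oc2ncnc3[nH]ccc23)cc1`, gives 3200 nM in this assay. Compound 2, with the structure `Cc1ccccc1Oc1ncnc2[nH]ccc12`, reaches only the limit of this assay, reported as > 32000 nM, so no number is known for it. Within the data shown here, the single change between these two is methyl in place of hydrogen on an aromatic carbon, and it produced an at least 10-fold higher number from compound 1 to compound 2 (1.00 log units; beyond the scatter), which fits (the limit of > 32000 nM in this assay, at which 1 of the 3 values shown sits).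

Among the measured compounds shown here, compound 3, with the structure `Cc1cc2c(Oc3ccc(F)cc3F)ncnc2[nH]1`, gives 1200 nM in this assay, the lowest of the two numbers known so far. The difference between the core of compound 3 and the core of compound 1 is not broken down here.

Compound 4, with the structure `Cc1[nH]c2ncnc(Oc3ccc(F)cc3F)c2c1C`, is not yet measured. It differs from compound 3 by methyl in place of hydrogen on an aromatic carbon. For the measured compounds named here, this is the same kind of change as the one from compound 1 to compound 2, but not the same: there the methyl entered on a six-membered aromatic ring of carbon only, ortho to a large group, whereas here it enters on a five-membered aromatic ring with 1 nitrogen, part of a fused or bridged system of two rings, next to the ring atom that bears a methyl group, two ring bonds from the ring nitrogen. Going by the values given here, the only measured example of this kind of change is an at least 10-fold higher number from compound 1 to compound 2 (1.00 log units; beyond the scatter), which points toward a weaker number, yet it sits at a different place, so a smaller loss is expected: a 2.1-fold higher number from compound 3 to compound 4 (0.32 log units; beyond the scatter). On this basis compound 4 is estimated to give 2500 nM in this assay, with a likely range from 700 nM to 10000 nM.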

Compound 4, half-maximal inhibitory concentration: 2000 nM
The estimate for compound 4 lay 1.3-fold (0.10 log units) above the measured number, and the stated range covers the measured number.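

In this assay, methyl in place of hydrogen on the five-membered aromatic ring gives a 1.7-fold higher number from compound 3 to compound 4 (0.22 log units; within the scatter), so on this core the change costs nothing that can be told apart from the usual variation between repeat measurements. Set beside the earlier case, the same kind of change did not carry over from one core to the other with the same size: the same change on two cores in this assay, an at least 10-fold higher number (1.00 log units; beyond the scatter) from compound 1 to compound 2 and a 1.7-fold higher number (0.22 log units; within the scatter) from compound 3 to compound 4, at least 6.0-fold (0.77 log units) apart, beyond the scatter of two such steps. This does not show why the two steps differ, as they differ both in the core and in the ring that receives the methyl, and with only two pairs no rule can be drawn; moreover compound 2 stands at a limit of the assay rather than at a number, so the true size of the first step stays unknown: the limit of > 32000 nM in this assay, at which 1 of the 4 values shown sits.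

As far as these compounds go, what remains open is how other groups at this same place on the five-membered ring, such as an ethyl group, an amine or a carboxylic acid, would read in this assay. Also open, from the compounds shown here alone, is whether the large loss would return if a methyl entered the six-membered aromatic ring of carbon only in a compound with the core of compound 3.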